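The compounds below may be only part of what the source reports. "The series", "measured", "known", "first", "only" and "open" are said of these compounds alone.

Measured so far in an assay on LtK cells with ATP-sensitive inward rectifier potassium channel 11 (Homo sapiens) as the target; on this read-out higher numbers stand for an effect only at larger amounts of compound and lower numbers for an effect already at smaller amounts:

Compound 1, `CCCC(C)C(=O)Nc1c(C(O)(C(F)(F)F)C(F)(F)F)ccc2ccccc12`, gives > 10000 nM, which is a limit of the assay rather than a number.
Compound 2, `O=C(Nc1c(C(O)(C(F)(F)F)C(F)(F)F)ccc2ccccc12)C1CCC1`, gives 45 nM.
Compound 3, `Cc1ccccc1C(=O)Nc1c(C(O)(C(F)(F)F)C(F)(F)F)ccc2ccccc12`, gives 5550 nM.

All three share the same core and differ only in the group attached to the carbonyl carbon of the amide. Among the two numbers, compound 2 stands lowest; its nearest neighbour is compound 3, reached by a step of a 120-fold higher number from compound 2 to compound 3 (2.09 log units; beyond the scatter). Compound 1 sits at the limit of > 10000 nM in this assay, at which 1 of the 3 values shown sits.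

Compound 4, `O=C(Nc1c(C(O)(C(F)(F)F)C(F)(F)F)ccc2ccccc12)c1cccc([N+](=O)[O-])c1`, is the next member of the series. Its change from compound 2 is 3-nitrophenyl in place of cyclobutyl on a carbonyl carbon. For the measured compounds named here, the measured step that bears most on it is the one from compound 2 to compound 3, where a cyclobutyl group was likewise exchanged for an aromatic ring and the number rose by a 120-fold higher number from compound 2 to compound 3 (2.09 log units; beyond the scatter). The step from compound 1 to compound 3, an at least 1.8-fold lower number from compound 1 to compound 3 (0.25 log units; that floor lies within the scatter), shows that the aromatic amide stayed far from the number of compound 2. A large rise in this assay is therefore expected for compound 4, of about a 33-fold higher number from compound 2 to compound 4 (1.52 log units; beyond the scatter). Compound 4 is estimated to give 1500 nM, within a range from 200 nM to 10000 nM.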

Compound 4, half-maximal effective concentration: 117 nM
The estimate for compound 4 lay 13-fold (1.11 log units) above the measured number; measured number outside the range, below it.
By their numbers in this assay, from the lowest: compound 2; then compound 4; then compound 3. At a limit, above all of these: compound 1.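

In this assay, an aromatic ring on the carbonyl carbon does not by itself bring a large rise: exchanging cyclobutyl for 3-nitrophenyl gives only a 2.6-fold higher number from compound 2 to compound 4 (0.41 log units; beyond the scatter), so the large rise seen with compound 3 does not hold for every aromatic ring. Which aromatic ring is present clearly matters at this position, with 3-nitrophenyl in place of 2-methylphenyl giving a 47-fold lower number from compound 3 to compound 4 (1.68 log units; beyond the scatter). Exchanging 1-methylbutyl for 3-nitrophenyl gives an at least 85-fold lower number from compound 1 to compound 4 (1.93 log units; beyond the scatter), which is only a floor for the true size, as compound 1 stands at a limit of the assay and not at a number: the limit of > 10000 nM in this assay, at which 1 of the 4 values shown sits.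

Compound 3 and compound 4 differ both in the group carried by the ring and in where it sits, so these two compounds cannot show which of the two differences accounts for their gap. A 3-methylphenyl or a 2-nitrophenyl group would separate the two, while an unsubstituted phenyl ring or a 3-cyanophenyl group would test whether the nitro group is needed at all.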